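Swapping thiophene for furan on a weakly antiproliferative core

The source may report more compounds than this note shows. Statements on the series, on what has been measured and on what is new or still open speak of the compounds shown alone.

Measured compounds:
compound 1 `c1coc(-c2ccnc(-c3cccs3)c2)c1` gives 118000 nM in a functional assay on SK-MEL-2 cells (Homo sapiens) for antiproliferative activity; on this read-out lower numbers stand for an effect already at smaller amounts and higher numbers for an effect only at larger amounts of compound
compound 2 `c1ccc(-c2cc(-c3cccs3)cc(-c3ccco3)n2)cc1` gives 118000 nM in this assay
compound 3 `C(=C/c1ccco1)\c1cc(-c2ccco2)cc(-c2cccs2)n1` gives 118000 nM in this assay

All three measured compounds share a central ring carrying a furan-2-yl group and a thiophen-2-yl group, and every one of them reaches the same reading in this assay. Compound 1 is the smallest of the three, and its value is level with that of compound 2 and that of compound 3, the differences lying within the usual scatter. Going by the values given here, the one step that can be followed, no change at the digits printed from compound 1 to compound 3 (within the scatter), shows that adding a 2-(furan-2-yl)ethenyl group on an aromatic carbon left the reading where it was.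

Compound 4 `c1coc(-c2ccnc(-c3ccco3)c2)c1` differs from compound 1 only in one place: furan-2-yl in place of thiophen-2-yl on an aromatic carbon. Among the compounds with values here, no measured pair speaks directly to replacing one five-membered hetero-aromatic ring by another, but the only measured step, from compound 1 to compound 3, moved nothing, and the readings of compound 2 and compound 3 sit at the same level as compound 1. With nothing pointing in either direction, the step of no change at the digits printed from compound 1 to compound 4 (within the scatter) is expected to stay within the scatter.

The value of compound 4 in this assay is therefore estimated at 118000 nM, with a range from 60000 nM to 236000 nM.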

Compound 4, half-maximal effective concentration: 118000 nM
Compound 4: the middle estimate sits on the measured number at the digits printed; the range from low to high includes it.
By their numbers in this assay, from the lowest: compounds 1, 2, 3 and 4 (each within the scatter of the next).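

In this assay, exchanging thiophen-2-yl for furan-2-yl on the aromatic carbon next to the ring nitrogen gives no change at the digits printed from compound 1 to compound 4 (within the scatter). Going by these compounds alone, this is the first direct test of this place: with sulfur or oxygen in the five-membered aromatic ring, and with the heavy-atom count the same, the reading stays level, whereas the earlier step replaced a hydrogen with a larger group rather than exchanging one ring for another. No measurement on hand explains why the two rings read alike.

Going by these compounds, all four compounds share a single printed number, so it remains open whether any change at this place can shift the reading at all, or whether this series simply gives no separation in this assay. A group of a different kind in place of the thiophen-2-yl, such as an amine, a carboxylic acid or a longer chain, would show whether this position responds to anything beyond swapping one five-membered aromatic ring for another.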